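The compounds below may be only part of what the source reports. "The series", "measured", "known", "first", "only" and "open" are said of these compounds alone.

Compound 1 `COc1ccc(-c2c(S(=O)(=O)c3ccc(C)c(F)c3)cnc3c(F)cccc23)cc1`, compound 2 `COc1ccc(S(=O)(=O)c2cnc3c(F)cccc3c2-c2cccc(Cl)c2)cc1` and compound 3 `COc1ccc(-c2c(S(=O)(=O)c3cc(Cl)cc(Cl)c3)cnc3c(F)cccc23)cc1` have been measured in an ADME assay on microsomes from liver (Homo sapiens) for metabolic stability, tested at 2.5 uM; a higher number here means faster removal of the compound, a lower number slower removal. Compound 1 gives 3.27 mL/min, compound 2 gives 2.75 mL/min, and compound 3 gives 2.11 mL/min.

Compound 3 has the lowest of the three numbers, but its nearest neighbour is compound 2, and its furthest is compound 1, and both gaps are within the scatter of this assay, so the three compounds cannot be set in order on these data.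

Compound 4 `COc1ccc(-c2c(S(=O)(=O)c3ccc(OC)cc3)cnc3c(F)cccc23)cc1` is the next compound. It differs from compound 3 in one place: 4-methoxyphenyl in place of 3,5-dichlorophenyl on a sulfonyl sulfur.

For the measured compounds named here, one measured step touches the same position: a 1.5-fold lower number from compound 1 to compound 3 (0.19 log units; within the scatter). That step sits within the scatter, so an exchange of the ring on the sulfonyl sulfur has not yet shown a clear effect here. For compound 4 the expected step is therefore a 1.3-fold higher number from compound 3 to compound 4 (0.12 log units; within the scatter), with no clear direction beyond the scatter. The estimate for compound 4 in this assay is 2.8 mL/min, expected to fall between 1.6 mL/min and 5 mL/min.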

Compound 4, intrinsic clearance in a liver preparation (reported as CLH), per the amount of preparation that the assay uses: 2.12 mL/min
Compound 4: the middle estimate sits 1.3-fold (0.12 log units) above what was measured; the range from low to high includes it.
By their numbers in this assay, from the lowest: compounds 3, 4, 2 and 1 (each within the scatter of the next).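

Putting 4-methoxyphenyl in place of 3,5-dichlorophenyl on a sulfonyl sulfur exchanges chlorine for oxygen, yet this assay shows no readable difference (a 1.0-fold higher number from compound 3 to compound 4 (0.00 log units; within the scatter)). The same holds with 3-fluoro-4-methylphenyl as the group replaced (a 1.5-fold lower number from compound 1 to compound 4 (0.19 log units; within the scatter)), so across compound 1, compound 3 and compound 4, the ring at this position has no clear effect on the number. For the compounds shown here, the first look at the ring on an aromatic carbon, where 4-methoxyphenyl takes the place of 3-chlorophenyl while the sulfonyl ring also differs in its name only by position on the core, likewise stays within the scatter (a 1.3-fold lower number from compound 2 to compound 4 (0.11 log units; within the scatter)).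

Nothing available explains why these numbers lie so close together. Going by these compounds, whether a ring carrying an amine or a carboxylic acid on the sulfonyl sulfur would give a step beyond the scatter remains open.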